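Fluorine in place of a nitrile on the sulfonyl ring

The source may report more compounds than this note shows. Statements on the series, on what has been measured and on what is new or still open speak of the compounds shown alone.

Compound 1 `CCN(CC)c1ccc2cc(C(=O)c3ccc(N4CCN(C(=O)CN5CCNCC5)CC4)cc3)oc2c1` was tested in an ADME assay on L02 cells (Homo sapiens) for cytotoxicity, read by MTT assay, with a stated time of 48 h; a higher number here means a weaker inhibitor, a lower number a stronger inhibitor; compound 1 gives > 100000 nM, which is a limit of the assay rather than a number (the limit of > 100000 nM in this assay, at which 1 of the 3 values shown sits). Compound 2 `CCN(CC)c1ccc2cc(C(=O)c3ccc(N4CCN(C(=O)CN5CCN(C(=O)CCl)CC5)CC4)cc3)oc2c1` gives 20900 nM in this assay, and compound 3 `CCN(CC)c1ccc2cc(C(=O)c3ccc(N4CCN(C(=O)CN5CCN(S(=O)(=O)c6ccc(C#N)cc6)CC5)CC4)cc3)oc2c1` gives 44100 nM in this assay. Compound 3 holds the highest of the two numbers shown; the step of a 2.1-fold higher number from compound 2 to compound 3 (0.32 log units; beyond the scatter) is its nearest neighbour. The measured steps of an at least 4.7-fold lower number from compound 1 to compound 2 (0.67 log units; beyond the scatter) and an at least 2.2-fold lower number from compound 1 to compound 3 (0.35 log units; beyond the scatter) both change the group on an amine nitrogen in a ring. Compound 4 `CCN(CC)c1ccc2cc(C(=O)c3ccc(N4CCN(C(=O)CN5CCN(S(=O)(=O)c6ccc(F)cc6)CC5)CC4)cc3)oc2c1` differs from compound 3 by fluoro in place of cyano on an aromatic carbon. Among the compounds with values here, no measured step touches that aromatic position, so none bears directly on this change. For compound 4 in this assay a step within the scatter is expected, a 1.0-fold lower number from compound 3 to compound 4 (0.00 log units; within the scatter). Compound 4 is therefore estimated at 44000 nM, between 18000 nM and 100000 nM.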

Compound 4, half-maximal inhibitory concentration: 9240 nM
Compound 4: middle estimate off by 4.8-fold (0.68 log units), on the high side; the measured number lies below the stated range.
By their numbers in this assay, from the lowest: compound 4; then compound 2; then compound 3. At a limit, above all of these: compound 1.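

On this aromatic carbon, the choice of group matters: in this assay, replacing the nitrile with fluoro gives a 4.8-fold lower number from compound 3 to compound 4 (0.68 log units; beyond the scatter). This single change also reverses the order seen earlier against the (chloromethyl)carbonyl group, with a 2.3-fold lower number from compound 2 to compound 4 (0.35 log units; beyond the scatter). Compound 1 carries a limit rather than a number, and the step from it reads an at least 10-fold lower number from compound 1 to compound 4 (1.03 log units; beyond the scatter).

As far as these compounds go, whether other groups on this carbon, such as chlorine, a methoxy group or an amine, would follow fluoro or the nitrile remains open. These compounds cannot show why the two groups differ.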